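A few compounds are considered here, and "the series" means these few. Any claim that something is new, unique, unknown or untested is made for them only; others in the source may bear on it.

Measured so far: compound 1 `Cc1nn(C(=O)C2CC2)c(N)c1-c1ccc(Cl)c(Cl)c1` gives 24300 nM in an assay on Sf9 cells for inhibition of mitogen-activated protein kinase kinase kinase 14 (Homo sapiens), read by ADP-Glo, with a stated time of 60 min; a lower number here means a stronger inhibitor, a higher number a weaker inhibitor; compound 2 `Cc1nn(C(=O)C2CCCC2)c(N)c1-c1ccc(Cl)c(Cl)c1` gives 41000 nM in this assay.

Compound 1 holds the lower of the two numbers, with compound 2 within the scatter of it: a 1.7-fold higher number from compound 1 to compound 2 (0.23 log units; within the scatter). Compound 3 `Cc1nn(C(=O)C2CC2)c(N)c1-c1ccc(Cl)cc1` differs from compound 1 by hydrogen in place of chloro on an aromatic carbon. That measured step concerns the ring on the carbonyl carbon, not the chloro on the aromatic ring, so it does not bear on this change and the data give no direction for it. Compound 3 is therefore estimated at 35000 nM, with a range from 10000 nM to 120000 nM. The expected step is a 1.4-fold higher number from compound 1 to compound 3 (0.16 log units; within the scatter), no larger than the scatter.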

Compound 3, half-maximal inhibitory concentration: > 100000 nM
Compound 3 ended at the assay's limit (the forecaster's own chance of this, stated with the estimate: 25%); middle value at least 2.8-fold (0.45 log units) from the limit.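

Hydrogen in place of chloro on this aromatic carbon, ortho to a chloro group and meta to a large group, gives an at least 4.1-fold higher number from compound 1 to compound 3 (0.61 log units; beyond the scatter). Going by these compounds alone, this is the first step beyond the scatter, so this chloro matters in a way that the ring change on the carbonyl carbon did not show. Compound 3 stands at a limit of this assay, not at a number, so the full size of the step stays unknown: the limit of > 100000 nM in this assay, at which 1 of the 3 values shown sits.

From the compounds shown here alone, whether a methyl, a methoxy or a nitrile at this position would keep the number of compound 1 remains open. Also open, going by these compounds, is what removing the remaining chloro would do.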